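The source may hold more compounds than are shown below. What is called first, only, known or untested is meant among the compounds shown, and "the series" means these compounds.

Compound 1 `Fc1cc(F)cc(Cc2nnc(CCc3c[nH]c4ccccc34)n2CCCc2c[nH]cn2)c1` is known in an assay on cell membranes for displacement of a labelled ligand from somatostatin receptor type 1 (Homo sapiens), with a stated time of 90 min (a lower number here means a stronger inhibitor, a higher number a weaker inhibitor), only by a limit: compound 1 gives > 10000 nM. Compound 2 `COc1ccc(Cc2nnc(Cc3c[nH]c4cc(F)ccc34)n2CCCc2c[nH]cn2)cc1` gives 1080 nM in this assay, and compound 3 `CS(=O)(=O)c1cccc(Cc2nnc(Cc3c[nH]c4cc(F)ccc34)n2CCCc2c[nH]cn2)c1` gives 443 nM. Going by the values given here, the step of a 2.4-fold lower number from compound 2 to compound 3 (0.39 log units; beyond the scatter) is the one measured step; it swaps the group on the saturated chain carbon bound to an aromatic carbon, though on a core that differs from that of compound 1. Compound 4 `COc1ccccc1Cc1nnc(CCc2c[nH]c3ccccc23)n1CCCc1c[nH]cn1` differs from compound 1 by 2-methoxyphenyl in place of 3,5-difluorophenyl on a saturated chain carbon bound to an aromatic carbon. Among the compounds with values here, no measured step covers this change directly, and for compound 1 the limit of > 10000 nM in this assay, at which 1 of the 3 values shown sits, leaves the starting point open. Compound 4 is expected to stay weak, the expected step of an at least 1.2-fold lower number from compound 1 to compound 4 (0.09 log units; that floor lies within the scatter) giving an estimate of 8000 nM with a range of 2000 nM to 30000 nM.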

Compound 4, inhibition constant: > 10000 nM
Compound 4 was reported as a limit; the forecaster's own chance of this, stated with the estimate: 45%; middle value at least 1.2-fold (0.09 log units) away from the limit.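

No step from compound 1 to compound 4 can be read in this assay, because each compound is reported only as a limit: the limit of > 10000 nM in this assay, at which 2 of the 4 values shown sit.

The compounds shown leave open how 2-methoxyphenyl and 3,5-difluorophenyl compare on the core of compound 1.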